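The source may report more compounds than this note shows. Statements on the series, on what has been measured and on what is new or still open speak of the compounds shown alone.

Measured in a functional assay on SW480 cells (Homo sapiens) for antiproliferative activity, read by sulforhodamine B assay, with a stated time of 48 h; on this read-out higher numbers stand for weaker inhibition and lower numbers for stronger inhibition:
Compound 1 `COc1cccc(/C=C/C(=O)C(=Cc2cc(OC)c(OC)c(OC)c2)C(=O)/C=C/c2cccc(OC)c2OC)c1OC`: 650 nM
Compound 2 `COc1cc(OC)c(C=C(C(=O)/C=C/c2cccc(OC)c2OC)C(=O)/C=C/c2cccc(OC)c2OC)c(OC)c1`: 840 nM
Compound 3 `COc1cc(C=C(C(=O)/C=C/c2cccc(OC)c2OC)C(=O)/C=C/c2cccc(OC)c2OC)cc(OC)c1O`: 420 nM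

Compound 3 stands within the scatter of both other compounds: a 1.5-fold lower number from compound 1 to compound 3 (0.19 log units; within the scatter), and a 2.0-fold lower number from compound 2 to compound 3 (0.30 log units; within the scatter). Compound 4 `COc1ccc(C=C(C(=O)/C=C/c2cccc(OC)c2OC)C(=O)/C=C/c2cccc(OC)c2OC)cc1O` has not been measured and differs from compound 3 in one place: 3-hydroxy-4-methoxyphenyl in place of 4-hydroxy-3,5-dimethoxyphenyl on a double-bonded chain carbon bound to a double-bonded chain carbon. There, 3-hydroxy-4-methoxyphenyl stands in place of 4-hydroxy-3,5-dimethoxyphenyl on a double-bonded chain carbon bound to a double-bonded chain carbon. The two steps to compound 3 changed this same group, as did a 1.3-fold higher number from compound 1 to compound 2 (0.11 log units; within the scatter), and all three stayed within the scatter. No step beyond the scatter is therefore expected in this assay. The expected step is a 1.2-fold higher number from compound 3 to compound 4 (0.08 log units; within the scatter). Compound 4 is estimated at 500 nM, with an expected range from 180 nM to 1400 nM.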

Compound 4, half-maximal inhibitory concentration: 320 nM
Estimate against measurement, compound 4: 1.6-fold (0.19 log units) above, within the range that was stated.
By their numbers in this assay, from the lowest: compounds 4, 3, 1 and 2 (each within the scatter of the next, the first and the last beyond it).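

In this assay, this position, on a double-bonded chain carbon bound to a double-bonded chain carbon, now shows steps beyond the scatter: a 2.6-fold lower number from compound 2 to compound 4 (0.42 log units; beyond the scatter) and a 2.0-fold lower number from compound 1 to compound 4 (0.31 log units; beyond the scatter) are both modest, while a 1.3-fold lower number from compound 3 to compound 4 (0.12 log units; within the scatter) stays within it. Compound 4 thus separates from the two trimethoxyphenyl compounds, compound 1 and compound 2, but not from compound 3, which also carries a hydroxy group on this ring. No evidence given here accounts for these steps. Still open, from the compounds shown here alone, is how an amine or a carboxylic acid on this ring, or a longer alkoxy chain in place of methoxy, would stand.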